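From cyano to chloro: one small change in compound 1

This account rests on a few compounds, and the source may have more. Where it says the series, first, only, none or still open, it means among the compounds named here.

Measured so far in a functional assay on HL-60 cells (Homo sapiens) for cytotoxicity, read by luminescence and CellTiter-Glo, with a stated time of 3 days; on this read-out higher numbers stand for weaker inhibition and lower numbers for stronger inhibition:
- compound 1 `N#Cc1cc(Cl)ccc1NC(=O)c1ccc2cccnc2c1O` gives 790 nM
- compound 2 `N#Cc1ccc(NC(=O)c2cc(Cl)ccc2O)cc1` gives 700 nM

These two numbers lie within the usual scatter of repeated measurements, so compound 1 cannot be separated from compound 2 on this evidence. Within the data shown here, compound 2 does not share the core of compound 1, and no pair of tested compounds differs in one place only. Among the measured compounds shown here, no measured step therefore shows what a single swap does here.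

The next compound to be tested, compound 3 `O=C(Nc1ccc(Cl)cc1Cl)c1ccc2cccnc2c1O`, keeps the core of compound 1 and makes one change (chloro in place of cyano on an aromatic carbon). In short, it has chloro in place of cyano on an aromatic carbon, ortho to a large group and meta to a chloro group.

With no measured swap as a guide, the expectation starts from compound 1 at 790 nM and stays cautious. The expected change is a 1.6-fold lower number from compound 1 to compound 3 (0.20 log units; within the scatter) in this assay, a step no larger than the scatter and leaning slightly toward stronger inhibition. For compound 3 the estimated value is 500 nM with an expected range from 150 nM to 1700 nM.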

Compound 3, half-maximal inhibitory concentration: 610 nM
Compound 3: middle estimate off by 1.2-fold (0.09 log units), on the low side, within the range that was stated.
By their numbers in this assay, from the lowest: compounds 3, 2 and 1 (each within the scatter of the next).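

In this assay, among these compounds, putting chloro in place of cyano gives a 1.3-fold lower number from compound 1 to compound 3 (0.11 log units; within the scatter), the first measured step in which only one place on the core of compound 1 differs. On this aromatic carbon, ortho to a large group and meta to a chloro group, the swap therefore gives no separable difference in the read-out, even though a group with a triple bond and a hydrogen-bond acceptor gives way to a smaller group with neither. No accompanying measurement bears on why the two compounds read so closely.

This single step cannot show whether other groups on the same carbon would also stay within the scatter, and an amine, a carboxylic acid or a longer chain there could give quite a different number. Among the compounds shown here, with only one swap on this core at hand, it also remains open whether any change at this place can move the read-out beyond the scatter, and whether changes elsewhere on the core would matter more.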